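Removing the benzyl from the amidine nitrogen

This account rests on a few compounds, and the source may have more. Where it says the series, first, only, none or still open, it means among the compounds named here.

Measured compounds:
In a functional assay on HeLa cells (Homo sapiens) for cytotoxicity, read by MTT assay, with a stated time of 48 h (on this read-out lower numbers stand for stronger inhibition and higher numbers for weaker inhibition), compound 1 `COc1ccc(N/C(CCNC2=CC(=O)c3ccccc3C2=O)=N\S(=O)(=O)c2ccc(C)cc2)cc1` gives 7590 nM.
Compound 2 `Cc1ccc(S(=O)(=O)/N=C(/CCNC2=CC(=O)c3ccccc3C2=O)NCc2ccccc2)cc1` gives 3980 nM.

Compound 2 stands at the lower of the two numbers, but that gap lies within the scatter: a 1.9-fold lower number from compound 1 to compound 2 (0.28 log units; within the scatter). Compound 3 `Cc1ccc(S(=O)(=O)/N=C(\N)CCNC2=CC(=O)c3ccccc3C2=O)cc1` differs from compound 2 by hydrogen in place of benzyl on an amine nitrogen. For the measured compounds named here, only one measured step exists, a 1.9-fold lower number from compound 1 to compound 2 (0.28 log units; within the scatter), and it swaps one group for another at that nitrogen rather than removing it, so it bears on this change only loosely. Compound 3 is therefore estimated at 8000 nM, with a range of 3000 nM to 25000 nM, an expected step of a 2.0-fold higher number from compound 2 to compound 3 (0.30 log units; within the scatter) that may not exceed the scatter.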

Compound 3, half-maximal inhibitory concentration: 24600 nM
The estimate for compound 3 lay 3.1-fold (0.49 log units) below the measured number; measured number inside the range.
By their numbers in this assay, from the lowest: compounds 2 and 1 (each within the scatter of the next); then compound 3.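

In this assay, removing the group from this amine nitrogen altogether weakens the compound, with a 6.2-fold higher number from compound 2 to compound 3 (0.79 log units; beyond the scatter) and a 3.2-fold higher number from compound 1 to compound 3 (0.51 log units; beyond the scatter). Benzyl and 4-methoxyphenyl could not be told apart earlier, but these steps show that either group gives a lower number than hydrogen at this nitrogen. Nothing available here explains this difference. The compounds shown leave open whether a group as small as methyl would keep the lower number, or whether a cyclohexyl group, which has a ring but no aromatic one, would do the same.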